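Replacing an iodophenyl with a methylphenyl in compound 3

The compounds below may be only part of what the source reports. "The series", "measured", "known", "first", "only" and "open" are said of these compounds alone.

Among the compounds with values here, compound 2 `Cc1ccc(S(=O)(=O)/N=C(/CCNC2=CC(=O)c3ccccc3C2=O)Nc2ccccc2I)cc1` is the weaker of the two compounds measured so far in a functional assay on HeLa cells (Homo sapiens) for cytotoxicity, read by MTT assay, with a stated time of 48 h; a higher number here means a weaker inhibitor, a lower number a stronger inhibitor: compound 2 gives 19100 nM, while compound 1 `Cc1ccc(S(=O)(=O)/N=C(/CCNC2=CC(=O)c3ccccc3C2=O)Nc2ccccc2[N+](=O)[O-])cc1` gives 3310 nM. Within the data shown here, the one measured step, a 5.8-fold higher number from compound 1 to compound 2 (0.76 log units; beyond the scatter), shows that swapping the substituent on this aromatic ring moves the read-out well beyond the usual scatter. Compound 3 `Cc1ccc(S(=O)(=O)/N=C(/CCNC2=CC(=O)c3ccccc3C2=O)Nc2cccc(C)c2)cc1` differs from compound 2 by 3-methylphenyl in place of 2-iodophenyl on an amine nitrogen. Among the measured compounds shown here, no measured step tests a methyl group on this ring, so the only guide is that the substituent on the aryl ring matters and that the measured values span a modest range. The direction of the change for compound 3 is therefore uncertain. Compound 3 is expected to fall between the two measured values, estimated at 9000 nM, with a range from 2500 nM to 40000 nM. This corresponds to an expected step of a 2.1-fold lower number from compound 2 to compound 3 (0.33 log units; beyond the scatter).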

Compound 3, half-maximal inhibitory concentration: 9060 nM
Estimate against measurement, compound 3: 1.0-fold (0.00 log units) below, within the range that was stated.
By their numbers in this assay, from the lowest: compound 1; then compound 3; then compound 2.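

In this assay, the 3-methylphenyl group puts compound 3 in the middle of the three compounds, with a 2.1-fold lower number from compound 2 to compound 3 (0.32 log units; beyond the scatter) and a 2.7-fold higher number from compound 1 to compound 3 (0.44 log units; beyond the scatter). All three aryl groups on this amine nitrogen now give clearly separate read-outs, and an aryl group carrying only a methyl substituent lands inside the range set by the 2-nitrophenyl and 2-iodophenyl groups. Nothing available explains this order.

The step from 2-iodophenyl to 3-methylphenyl changes both the substituent and its number in the name, so these compounds cannot show how much each of those two changes contributes. Going by these compounds, a plain phenyl, a 2-methylphenyl or a 3-iodophenyl group would be needed to separate them, and the effect of a non-aromatic group, such as a longer alkyl chain, on this nitrogen remains open.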